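Ring-nitrogen substituent variation in the amide series

The source may hold more compounds than are shown below. What is called first, only, known or untested is meant among the compounds shown, and "the series" means these compounds.

Compound 3 `Cn1c(-c2ccc(NC(=O)CN3CCN(c4ccccc4)CC3)cc2)nc(-c2ccccc2)c1-c1ccccc1` gives 46.5% in a functional assay on HT-29 cells (Homo sapiens) for cytotoxicity, read by MTT assay, with a stated time of 24 h, tested at 6.4 ug/mL (a lower number here means a weaker effect, a higher number a stronger effect of the compound at the concentration tested), and stands highest of the three measured compounds. Compound 1 `CN1CCN(CC(=O)Nc2ccc(-c3nc(-c4ccccc4)c(-c4ccccc4)n3C)cc2)CC1` gives 28.8%, and compound 2 `CCN1CCN(CC(=O)Nc2ccc(-c3nc(-c4ccccc4)c(-c4ccccc4)n3C)cc2)CC1` gives 17.2%. The measured steps are a number 17.7 percentage points higher from compound 1 to compound 3 (beyond the scatter), a number 29.3 percentage points higher from compound 2 to compound 3 (beyond the scatter) and a number 11.6 percentage points lower from compound 1 to compound 2 (beyond the scatter), all at the same ring nitrogen. Compound 4 `COc1ccc(CN2CCN(CC(=O)Nc3ccc(-c4nc(-c5ccccc5)c(-c5ccccc5)n4C)cc3)CC2)cc1` changes that position: 4-methoxybenzyl in place of phenyl on an amine nitrogen in a ring. Within the data shown here, the steps to compound 3 show that phenyl on the ring nitrogen gave higher numbers than methyl or ethyl, but no measured step covers a benzyl-type group, and the step from compound 1 to compound 2 went downward. Compound 4 is therefore expected to sit near compound 3, with a step of a number 4.5 percentage points lower from compound 3 to compound 4 (within the scatter) judged no larger than the scatter. The estimate for compound 4 is 42%, with a range from 24% to 60%.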

Compound 4, a percentage reported as activity, at one concentration (the size of the read-out at that concentration, not a potency): 17.8%
The estimate for compound 4 lay 24.2 percentage points above the measured number; measured number outside the range, below it.
By their numbers in this assay, from the lowest: compounds 2 and 4 (each within the scatter of the next); then compound 1; then compound 3.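

In this assay an aromatic ring on this amine nitrogen does not by itself give the higher number: 4-methoxybenzyl in place of phenyl gives a number 28.7 percentage points lower from compound 3 to compound 4 (beyond the scatter) and the value of compound 3 stays alone at the top. The ethyl compound is not separated from the new one, with a number 0.6 percentage points higher from compound 2 to compound 4 (within the scatter) within the scatter, while the methyl compound stands apart with a number 11 percentage points lower from compound 1 to compound 4 (beyond the scatter) beyond it. No measured evidence accounts for these steps.

Going by these compounds, whether the loss goes with the methoxy group or with the carbon link to the ring stays open. Unsubstituted benzyl and 4-methoxyphenyl on the same nitrogen would separate the two.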